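One Carbon Less in the Side Chain

The source may hold more compounds than are shown below. What is called first, only, known or untested is meant among the compounds shown, and "the series" means these compounds.

Compound 1 `CC1(C)C(=O)N(CCCS(=O)(=O)O)C(=O)N1Cl`: > 336 h
Compound 2 `CC1(C)CC(=O)CC(C)(C)N1Cl`: < 24 h
Compound 3 `CC1(C)CN(CCS(=O)(=O)CCCS(=O)(=O)O)C(=O)N1Cl`: > 2680 h

Three compounds have been run in a physicochemical assay for metabolic stability, at 40 degrees C; on this read-out lower numbers stand for a shorter-lived compound and higher numbers for a longer-lived compound. For compound 1 the result > 336 h is a limit of the assay, not a number. For compound 2 the value < 24 h is likewise a limit. For compound 3 the value > 2680 h is a limit as well. Compound 1 therefore stands at the limit of > 336 h in this assay, at which 1 of the 3 values shown sits. Compound 3 stands at the limit of > 2680 h in this assay, at which 1 of the 3 values shown sits, and compound 2 at the limit of < 24 h in this assay, at which 1 of the 3 values shown sits. Compound 4 `CC1(C)C(=O)N(CCS(=O)(=O)O)C(=O)N1Cl` differs from compound 1 by sulfo in place of sulfomethyl on a saturated chain carbon, two bonds along the chain from an amide-type nitrogen in a ring. Within the data shown here, no pair differing in one place has been measured, so no step is known. The step that the limit leaves unreadable from compound 1 to compound 4 is estimated to stay within the usual scatter. Compound 4 is expected to give 500 h, in the range 200 h to 3000 h.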

Compound 4, half-life: 1560 h
Estimate against measurement, compound 4: 3.1-fold (0.49 log units) below; low and high end bracket the measured number.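

Among these compounds, compound 1 gives > 336 h, which is a limit and not a number, and no step from compound 1 to compound 4 can be read. The compounds shown leave open how large the effect of sulfo in place of sulfomethyl is on the half-life.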